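Notes on a chloro substitution in a small series

A few compounds are considered here, and "the series" means these few. Any claim that something is new, unique, unknown or untested is made for them only; others in the source may bear on it.

- compound 1 (`O=C(/C=C/c1cccnc1)NCCCCCc1ccc(S(=O)(=O)Nc2ccccc2)cc1`) gives 581 nM
- compound 2 (`O=C(/C=C/c1cccnc1)NCCCCCCc1ccc(S(=O)(=O)Nc2ccccc2)cc1`) gives 328 nM
- compound 3 (`O=C(/C=C/c1cccnc1)NCCCCCCc1cccc(S(=O)(=O)Nc2ccccc2)c1`) gives 6.73 nM

In a functional assay on DU-145 cells (Homo sapiens) for inhibition, read by CCK-8 assay, with a stated time of 72 h (a higher number here means a weaker inhibitor, a lower number a stronger inhibitor), compound 3 holds the lowest number of the three, and compound 2 and compound 1 both stand above it, beyond the scatter. Next comes compound 4 (`O=C(/C=C/c1cccnc1)NCCCCCCc1cccc(S(=O)(=O)Nc2ccc(Cl)cc2)c1`), which differs from compound 3 by chloro in place of hydrogen on an aromatic carbon and carries chloro in place of hydrogen on an aromatic carbon, para to a large group. Among the compounds with values here, no measured pair tests a change at this place. The estimated step, a 1.2-fold higher number from compound 3 to compound 4 (0.08 log units; within the scatter), is expected to stay within the scatter, with a wide margin on the weaker side. Compound 4 is expected at 8 nM as a central estimate, within an estimated range of 2 nM to 35 nM in this assay.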

Compound 4, half-maximal inhibitory concentration: 84.4 nM
Compound 4: middle estimate off by 11-fold (1.02 log units), on the low side; the measured number lies above the stated range.
By their numbers in this assay, from the lowest: compound 3; then compound 4; then compounds 2 and 1 (each within the scatter of the next).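

In this assay, the ring on the sulfonamide nitrogen proves sensitive at this place: phenyl to 4-chlorophenyl gives a 13-fold higher number from compound 3 to compound 4 (1.10 log units; beyond the scatter). One added chlorine atom, on an aromatic carbon para to a large group, is enough to move the number well beyond the scatter. Nothing available explains this loss of potency.

On these data alone, whether the loss is specific to chloro or follows from any group at this place remains open; fluoro, methyl or methoxy here would separate the two. As far as these compounds go, the effect of chloro on other carbons of this ring is also open.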